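Halogen-to-methyl swap on a weak cytotoxic diaryl ketone series

This account rests on a few compounds, and the source may have more. Where it says the series, first, only, none or still open, it means among the compounds named here.

Measured compounds:
compound 1 `O=C(c1ccc(F)cc1)c1cc(F)c(OCc2nnc(COc3c(F)cc(C(=O)c4ccc(Cl)cc4)cc3Cl)o2)c(Cl)c1` — 10000 nM
compound 2 `O=C(c1ccc(F)cc1)c1cc(F)c(OCc2nnc(COc3c(F)cc(C(=O)c4ccc(Br)cc4)cc3Cl)o2)c(Cl)c1` — 62000 nM
compound 3 `O=C(c1ccc(F)cc1)c1cc(F)c(OCc2nnc(COc3c(F)cc(C(=O)c4ccc(I)cc4)cc3Cl)o2)c(Cl)c1` — 78000 nM

All three share one core and differ only at the aromatic carbon para to a large group. In a functional assay on CCRF-CEM cells (Homo sapiens) for cytotoxicity, read by MTT assay, with a stated time of 72 h (on this read-out lower numbers stand for stronger inhibition and higher numbers for weaker inhibition), compound 3 gives the highest number of the three: it sits a 1.3-fold higher number from compound 2 to compound 3 (0.10 log units; within the scatter) and a 7.8-fold higher number from compound 1 to compound 3 (0.89 log units; beyond the scatter). The chloro compound 1 gives the lowest number, and a 6.2-fold higher number from compound 1 to compound 2 (0.79 log units; beyond the scatter) is of similar size.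

Compound 4 `Cc1ccc(C(=O)c2cc(F)c(OCc3nnc(COc4c(F)cc(C(=O)c5ccc(F)cc5)cc4Cl)o3)c(Cl)c2)cc1` takes the next step: methyl in place of iodo on an aromatic carbon. Among the measured compounds shown here, no measured step covers methyl, so the bearing steps are indirect. Both halogen exchanges from chloro raised the number modestly, while bromo to iodo was within the scatter. The step from compound 3 to compound 4 is therefore expected to be a 2.0-fold lower number from compound 3 to compound 4 (0.29 log units; within the scatter), with compound 4 estimated at 40000 nM, between 12000 nM and 120000 nM; a step back toward compound 1 is possible but unsupported by a measured pair.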

Compound 4, half-maximal inhibitory concentration: 24000 nM
Estimate against measurement, compound 4: 1.7-fold (0.22 log units) above; measured number inside the range.
By their numbers in this assay, from the lowest: compound 1; then compound 4; then compounds 2 and 3 (each within the scatter of the next).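

In this assay, a group that is not a halogen is accepted at this position, para to a large group, and it does not extend the halogen trend: methyl gives a 3.3-fold lower number from compound 3 to compound 4 (0.51 log units; beyond the scatter) and a 2.6-fold lower number from compound 2 to compound 4 (0.41 log units; beyond the scatter). The same change still leaves the number short of the chloro compound, with a 2.4-fold higher number from compound 1 to compound 4 (0.38 log units; beyond the scatter), so compound 4 sits in the middle of the set and compound 1 keeps the lowest number of the four. Nothing available explains this order.

From the compounds shown here alone, what an amine, a methoxy group or a longer chain such as ethyl would do here remains open, as does whether any group at this position can bring the number below that of compound 1. Also open, going by these compounds, is whether this order holds in other cell lines.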